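The source may hold more compounds than are shown below. What is called first, only, known or untested is meant among the compounds shown, and "the series" means these compounds.

Compound 1, with the structure `CCCCNc1nc(N)nc(C)c1CCCN1CCN(C)CC1`, was tested in an assay on HEK293 cells for agonist activity at Toll-like receptor 8 (Homo sapiens), read by spectrophotometry (a higher number here means that more compound is needed for the effect, a lower number that less compound is needed), and gave 179 nM. Among the three measured compounds it holds the second highest number. Compound 2, `CCCCNc1nc(N)nc(C)c1CCCN1C(=O)c2ccccc2C1=O`, gave 453 nM in this assay, a higher number than compound 1 by more than the usual scatter. Compound 3, `CCCCNc1nc(N)nc(C)c1CCCN1Cc2ccccc2C1`, gave 29 nM, a lower number than compound 1 by a margin well beyond the scatter, so of the three it needs the least compound for the effect.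

The unmeasured compound 4, `CCCCNc1nc(N)nc(C)c1CCCC(C)(C)O`, shares the core of compound 1 and the same saturated chain, but the group at the end of that chain is swapped: 1-hydroxy-1-methylethyl in place of 4-methylpiperazin-1-yl on a saturated chain carbon, three bonds along the chain from an aromatic carbon. Among the measured compounds shown here, no pair of measured compounds differs by exactly this kind of swap, so the measured numbers give no direct guide. Compounds 2 and 3 both carry a ring at that position, as does compound 1, and their numbers spread widely in both directions from compound 1, which leaves the effect of removing the ring open.

The expectation for the step from compound 1 to compound 4 is therefore a 1.1-fold lower number from compound 1 to compound 4 (0.05 log units; within the scatter), a change not beyond the scatter. Compound 4 is estimated to give 160 nM in this assay, within a range from 40 nM to 650 nM.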

Compound 4, half-maximal effective concentration: 1220 nM
Beside the measured number, compound 4's estimate is 7.6-fold (0.88 log units) below it, outside the stated range (above it).
By their numbers in this assay, from the lowest: compound 3; then compound 1; then compound 2; then compound 4.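

The swap of 4-methylpiperazin-1-yl for 1-hydroxy-1-methylethyl on a saturated chain carbon, three bonds along the chain from an aromatic carbon, gives a 6.8-fold higher number from compound 1 to compound 4 (0.83 log units; beyond the scatter) in this assay, so the group at the end of this chain can move the number well beyond the scatter even when it has no ring. Among the compounds shown here, all the earlier end groups carried a ring, and compound 4 is the first without one; its number is the highest of the four, above that of compound 2 at 453 nM in this assay. This single step changes several things at once: the entering group has no ring and fewer heavy atoms, it holds oxygen where the leaving group held nitrogen, and it brings a hydrogen-bond donor that the leaving group lacks.

The compounds shown leave open which of these changes counts most, and where an open-chain amine such as dimethylamino at the end of the chain would stand in this series. Nothing measured here explains the step.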